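Naphthalenyl for chlorophenyl: an expected shift in lipophilicity

The compounds below may be only part of what the source reports. "The series", "measured", "known", "first", "only" and "open" are said of these compounds alone.

The account concerns two measured compounds and one that awaits measurement. Compound 1 `CC(=N)Nc1cccc(C(=O)NNC(=O)CC(CC(=O)O)c2ccc(-c3ccccc3)cc2)c1` gives 3.11 in a physicochemical assay for lipophilicity; on this read-out higher numbers stand for higher lipophilicity and lower numbers for lower lipophilicity. Compound 2 `N=C(N)Nc1cccc(C(=O)NNC(=O)NC(CC(=O)O)c2ccc(Cl)cc2)c1` gives 1.26 in this assay, which is the lowest of the two numbers shown; compound 1 stands a good deal higher, a gap that is beyond the usual scatter. The two compounds differ in several places at once, so nothing more than the two values themselves can be read from this comparison.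

Compound 3 `N=C(N)Nc1cccc(C(=O)NNC(=O)NC(CC(=O)O)c2cccc3ccccc23)c1` has not yet been measured in this assay. It differs from compound 2 in one place only: naphthalen-1-yl in place of 4-chlorophenyl on a saturated chain carbon bound to an amide-type nitrogen and a saturated chain carbon. Among the measured compounds shown here, no measured pair here shares this kind of change, so the expectation for the step rests on the structural change alone. The account expects a step upward from compound 2 to compound 3 of a number 0.54 log units higher from compound 2 to compound 3 (beyond the scatter) in this assay, a shift beyond the scatter but well short of the gap between compound 2 and compound 1. Accordingly, compound 3 is estimated at 1.8 in this assay, with a range from 1.3 to 2.3.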

Compound 3, partition coefficient: 1.7
Beside the measured number, compound 3's estimate is 0.10 log units above it, and the stated range covers the measured number.
By their numbers in this assay, from the lowest: compound 2; then compound 3; then compound 1.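

In this assay, among the compounds shown here, the exchange of 4-chlorophenyl for naphthalen-1-yl on a saturated chain carbon bound to an amide-type nitrogen and a saturated chain carbon is the first change at this position that can be read on its own, and it comes out as a number 0.44 log units higher from compound 2 to compound 3 (beyond the scatter). The earlier comparison, compound 1 against compound 2, mixed several differences at once and could not be assigned to any one place, whereas here a single exchange, from 7 heavy atoms with one aromatic ring to 10 heavy atoms with 2 aromatic rings, is tied to a modest step beyond the scatter. Nothing shown here bears on what lies behind the size of this step.

The compounds shown leave open how naphthalen-2-yl or an unsubstituted phenyl would read at this same position, and so whether the step belongs to naphthalen-1-yl in particular or would also appear with other aromatic groups. They also leave open whether the same exchange would give a step of similar size on the core of compound 1.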